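Series notes: the chain on the aromatic nitrogen

The source may report more compounds than this note shows. Statements on the series, on what has been measured and on what is new or still open speak of the compounds shown alone.

Among the measured compounds shown here, compound 1 `CCCCCCCCn1cc(/C=C/C(=O)c2ccc(NC(=O)CN3CCN(c4ccccc4OC)CC3)cc2)nn1` gives 26800 nM in a functional assay on HeLa cells (Homo sapiens) for inhibition, read by MTT assay (on this read-out higher numbers stand for weaker inhibition and lower numbers for stronger inhibition), the lowest of the two numbers known, with compound 2 `CCCCCCCCn1cc(/C=C/C(=O)c2ccc(NC(=O)CN3CCN(c4ccccc4)CC3)cc2)nn1` giving 33800 nM. For the measured compounds named here, the one measured step, a 1.3-fold higher number from compound 1 to compound 2 (0.10 log units; within the scatter), concerns a different part of the structure and does not bear on compound 3 `COc1ccccc1N1CCN(CC(=O)Nc2ccc(C(=O)/C=C/c3cn(Cc4ccc(Br)cc4)nn3)cc2)CC1`, whose change from compound 1 is 4-bromophenyl in place of heptyl on a saturated chain carbon bound to an aromatic nitrogen. No measured pair varies this saturated chain carbon, so nothing shown supports a step in either direction beyond the scatter. Compound 3 is therefore expected at 27000 nM, within 7000 nM to 100000 nM. The step of a 1.0-fold higher number from compound 1 to compound 3 (0.00 log units; within the scatter) is an estimate only, held wide.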

Compound 3, half-maximal inhibitory concentration: 26400 nM
The estimate for compound 3 lay 1.0-fold (0.01 log units) above the measured number, and the stated range covers the measured number.
By their numbers in this assay, from the lowest: compounds 3, 1 and 2 (each within the scatter of the next).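

At this saturated chain carbon bound to an aromatic nitrogen, the first measured change, 4-bromophenyl in place of heptyl, gives a 1.0-fold lower number from compound 1 to compound 3 (0.01 log units; within the scatter) in this assay and stays within the scatter. On this read-out, the ring-bearing 4-bromobenzyl and the open-chain octyl are therefore not told apart on the core of compound 1. No measurement at hand offers an explanation for this result.

Open, as far as these compounds go, is whether an amine, a carboxylic acid or a shorter chain here would move the number beyond the scatter. Also open, from the compounds shown here alone, is whether plain benzyl would match 4-bromobenzyl.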